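Oxadiazole for Pyrimidine on the Ring Nitrogen

A few compounds are considered here, and "the series" means these few. Any claim that something is new, unique, unknown or untested is made for them only; others in the source may bear on it.

Two compounds carry numbers in a functional assay on CHO-K1 cells for agonist activity at Glucose-dependent insulinotropic receptor (Homo sapiens), read by HTRF and cAMP accumulation, with a stated time of 30 min; a higher number here means a larger maximal response, a lower number a smaller maximal response. Compound 1 `CC(C)(C)OC(=O)N1CCC(CCCCNc2ccc3c(c2)CCS3(=O)=O)CC1` gives 62% in this assay. Among the compounds with values here, compound 2 `COc1cnc(N2CCC(CCCNc3ccc4c(c3)OCC4=O)CC2)nc1` gives 101% in this assay, the higher of the two numbers, and the only other number, that of compound 1, sits lower by an amount beyond the scatter. No two measured compounds differ in a single place, so the weight of any one change on the maximal response is not shown by these data. Compound 3 `CC(C)c1noc(N2CCC(CCCNc3ccc4c(c3)OCC4=O)CC2)n1` has not been measured. It differs from compound 2 by 3-isopropyl-1,2,4-oxadiazol-5-yl in place of 5-methoxypyrimidin-2-yl on an amine nitrogen in a ring. Without a measured step to lean on, the expected step of a number 11 percentage points lower from compound 2 to compound 3 (beyond the scatter) is taken as small, downward if anything, and quite possibly within the scatter. Compound 3 is therefore estimated at 90%, with a range from 65% to 110%.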

Compound 3, largest response reached (Emax), in percent of the reference or control that the assay uses: 94%
Compound 3: middle estimate off by 4 percentage points, on the low side, and the stated range covers the measured number.
By their numbers in this assay, from the lowest: compound 1; then compounds 3 and 2 (each within the scatter of the next).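

Within the data shown here, at the amine nitrogen in a ring, 3-isopropyl-1,2,4-oxadiazol-5-yl in place of 5-methoxypyrimidin-2-yl gives, in this assay, a number 7 percentage points lower from compound 2 to compound 3 (within the scatter), the only single-place step so far. The maximal response therefore holds when a six-membered aromatic ring with 2 hetero atoms gives way to a five-membered aromatic ring with 3 hetero atoms, with the counts of heavy atoms, donors and acceptors the same in both groups. Nothing at hand gives a reason for this tolerance.

Open, on these data alone, is whether the same nitrogen keeps this response with a group of another kind, such as an acetyl group or a group bearing a carboxylic acid. The step also leaves the shared core untouched, so the part played by the core in the maximal response stays unread.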